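This account rests on a few compounds, and the source may have more. Where it says the series, first, only, none or still open, it means among the compounds named here.

Working notes on the series. The shared core is that of compound 1 `O=C1O[C@@H](CO)CN1c1ccc(-n2cc(-c3ccccn3)cn2)c(F)c1`. In an ADME assay on HEK293-A cells (Homo sapiens) for cytotoxicity, read by MTT assay, with a stated time of 48 h (on this read-out lower numbers stand for stronger inhibition and higher numbers for weaker inhibition), compound 1 gives > 400 ug/mL, which is a limit of the assay rather than a number. Compound 2 `CN(CCC#N)C[C@H]1CN(c2ccc(-n3cc(-c4ccccn4)cn3)c(F)c2)C(=O)O1` gives > 400 ug/mL in this assay, also a limit. Compound 3 `O=C1O[C@@H](CN2CCCCC2)CN1c1ccc(-n2cc(-c3ccccn3)cn2)c(F)c1` gives > 400 ug/mL in this assay, again a limit. Compound 4 `O=C(NC[C@H]1CN(c2ccc(-n3cc(-c4ccccn4)cn3)c(F)c2)C(=O)O1)C(F)F` is not yet measured in this assay and differs from compound 1 by ((difluoromethyl)carbonyl)amino in place of hydroxy on a saturated chain carbon bound to a saturated ring carbon. The measured changes at the same place, a step that the two limits leave unreadable from compound 1 to compound 2, a step that the two limits leave unreadable from compound 1 to compound 3 and a step that the two limits leave unreadable from compound 2 to compound 3, carry no readable size because of the limit of > 400 ug/mL in this assay, at which 3 of the 3 values shown sit. No step beyond the scatter is therefore expected for compound 4, the expected step being a number no higher from compound 1 to compound 4 (the limit leaves the size open). Compound 4 is estimated at 400 ug/mL, between 250 ug/mL and 800 ug/mL, most likely reported as a limit again.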

Compound 4, half-maximal inhibitory concentration: 167 ug/mL
Compound 4: the middle estimate sits 2.4-fold (0.38 log units) above what was measured, and the stated range ends above it.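

In this assay, this position gives its first readable change: ((difluoromethyl)carbonyl)amino in place of hydroxy gives an at least 2.3-fold lower number from compound 1 to compound 4 (0.37 log units; beyond the scatter). The same group gives an at least 2.3-fold lower number from compound 3 to compound 4 (0.37 log units; beyond the scatter) in place of piperidin-1-yl, and an at least 2.3-fold lower number from compound 2 to compound 4 (0.37 log units; beyond the scatter) in place of (2-cyanoethyl)(methyl)amino, so a change at this place can bring the value down from the limit. The steps among compounds 1, 2 and 3 remain unreadable because those compounds share one limit: the limit of > 400 ug/mL in this assay, at which 3 of the 4 values shown sit.

As far as these compounds go, the full size of the new steps stays open. Also open, from the compounds shown here alone, is whether the fluorines or the carbonylamino link accounts for the fall; an acetylamino or plain amino group at this place would separate the two.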